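The source may hold more compounds than are shown below. What is called first, only, known or untested is meant among the compounds shown, and "the series" means these compounds.

Measured compounds in the series:

- compound 1, `CC(=O)Nc1ccc2cccc(S(=O)(=O)Nc3onc(C)c3C)c2c1`: in an assay on thoracic aorta for binding affinity to Endothelin-1 receptor (Rattus norvegicus) (a lower number here means a stronger inhibitor, a higher number a weaker inhibitor), compound 1 gives 870 nM
- compound 2, `Cc1noc(NS(=O)(=O)c2ccc3cccc(N)c3c2)c1C`: in this assay compound 2 gives 9800 nM

Compound 2 has the higher of the two numbers, and its gap to compound 1 lies beyond the scatter of repeated measurements. The two compounds differ in more than one place, so the two values are taken as they stand and nothing is read into the gap as a single step.

Compound 3, `Cc1noc(NS(=O)(=O)c2ccc3cccc(N(C)C)c3c2)c1C`, is the next compound to be measured in this assay. It is made from compound 2 by one change: dimethylamino in place of amino on an aromatic carbon. Within the data shown here, no step between measured compounds isolates this kind of change, so the expectation rests on the whole set. Compound 1, which carries a substituted nitrogen where compound 2 has the free amine, sits at a lower number; on that basis a drop in the number for compound 3 relative to compound 2 is expected, of moderate size, though a result within the scatter of compound 2 is also possible. The estimated step is a 3.3-fold lower number from compound 2 to compound 3 (0.51 log units; beyond the scatter) for compound 3. Compound 3 is expected to give about 3000 nM in this assay, within a range of 800 nM to 12000 nM.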

Compound 3, half-maximal inhibitory concentration: 31500 nM
For compound 3 the middle estimate is 11-fold (1.02 log units) below the measured one, outside the stated range (above it).
By their numbers in this assay, from the lowest: compound 1; then compound 2; then compound 3.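

Among these compounds, at this aromatic carbon, in this assay, dimethylamino in place of amino gives a 3.2-fold higher number from compound 2 to compound 3 (0.51 log units; beyond the scatter), the first step that isolates a single change, and it runs toward a weaker inhibitor. The change replaces one heavy atom carrying a hydrogen-bond donor with three heavy atoms and no donor, while the acceptor count and the absence of net charge stay the same, so this one step cannot separate the loss of the donor from the added carbons. Nothing measured here bears on the reason for the rise in the number.

Still open, from the compounds shown here alone, is where methylamino at this position would fall relative to compound 2 and compound 3, which would show whether one methyl on the nitrogen already moves the number. Also open, going by these compounds, is what a carbonyl-bearing group such as acetylamino would do at this same position on the core of compound 2; compound 1 differs from compound 2 in more than one place and does not settle this.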